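The source may hold more compounds than are shown below. What is called first, only, known or untested is meant among the compounds shown, and "the series" means these compounds.

Measured so far in a functional assay on HEK293 cells for agonist activity at Vasopressin V2 receptor (Homo sapiens), read by a luciferase reporter and cAMP accumulation; on this read-out lower numbers stand for an effect already at smaller amounts and higher numbers for an effect only at larger amounts of compound:
compound 1 `Cc1cc(C(=O)N2CCCCc3ccccc32)ccc1CNC(=O)Nc1c(F)cccc1F` gives 2.1 nM;
compound 2 `CCOC(=O)CNC(=O)NCc1ccc(C(=O)N2CCCCc3ccccc32)cc1C` gives 140 nM.

Going by the values given here, compound 2 stands at the higher of the two numbers, and its nearest neighbour, compound 1, lies far away, as the single step of a 67-fold higher number from compound 1 to compound 2 (1.82 log units; beyond the scatter) shows. The unmeasured compound 3 `Cc1cc(C(=O)N2CCCCc3ccccc32)ccc1CNC(=O)N1CCC[C@H]1C(=S)N(C)C` keeps the shared core of compound 2 and changes only the group on the carbonyl carbon: a group of 10 heavy atoms (7 carbon, 2 nitrogen, 1 sulfur; one five-membered non-aromatic ring with 1 hetero atom) in place of a group of 7 heavy atoms (4 carbon, 1 nitrogen, 2 oxygen; no ring), on a carbonyl carbon. Among the compounds with values here, the one measured step bears on this change only loosely, since it concerns the same carbonyl carbon but a different group leaving and entering; it does show that this part of the molecule moves the number a great deal. On that basis compound 3 is expected to land at a lower number than compound 2, with a step estimated as a 4.7-fold lower number from compound 2 to compound 3 (0.67 log units; beyond the scatter), though the direction is uncertain. For compound 3 the estimate in this assay is 30 nM, within a range of 5 nM to 300 nM.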

Compound 3, half-maximal effective concentration: 3.2 nM
For compound 3 the middle estimate is 9.4-fold (0.97 log units) above the measured one; measured number outside the range, below it.
By their numbers in this assay, from the lowest: compounds 1 and 3 (each within the scatter of the next); then compound 2.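

In this assay, the group with a five-membered non-aromatic ring on the carbonyl carbon restores what the ((ethoxycarbonyl)methyl)amino group lost, with a 44-fold lower number from compound 2 to compound 3 (1.64 log units; beyond the scatter). This shows that a low number at this position does not require the 2,6-difluorophenyl group, as a 1.5-fold higher number from compound 1 to compound 3 (0.18 log units; within the scatter) leaves compound 1 and compound 3 indistinguishable, even though the entering group has no aromatic ring and carries a sulfur and a defined stereocentre. Going by these compounds alone, nothing available here explains why this change moves the number so far.

The compounds shown leave open whether the sulfur matters, as they do not include the same group with oxygen in its place. They also leave open how the opposite configuration at the stereocentre, or a carboxylic acid on the ring, would read at this position.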